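Hydrogen for fluoro on the aryl thiourea: compound 4

The source may hold more compounds than are shown below. What is called first, only, known or untested is meant among the compounds shown, and "the series" means these compounds.

The series is aryl thioureas on the shared core of compound 1 `S=C(Nc1cccc(Br)c1)Nc1nc[nH]n1`, read in an ADME assay on MT4 cells (Homo sapiens) for cytotoxicity, read by MTT assay, with a stated time of 96 h; on this read-out higher numbers stand for lower toxicity in this test and lower numbers for higher toxicity in this test. Compound 1 gives 50000 nM in this assay. Compound 2 `COc1ccc(NC(=S)Nc2nc[nH]n2)cc1` sits at the limit of > 100000 nM. Compound 3 `Fc1ccc(NC(=S)Nc2nc[nH]n2)cc1` likewise sits at the limit of > 100000 nM. Going by the values given here, the only single-point step in the set, a step that the two limits leave unreadable from compound 2 to compound 3, is therefore not readable. Compound 4 `S=C(Nc1ccccc1)Nc1nc[nH]n1` differs from compound 3 by hydrogen in place of fluoro on an aromatic carbon. Among the compounds with values here, no measured step bears on this change, and the limit of > 100000 nM in this assay, at which 2 of the 3 values shown sit, shows that most of the series is not resolved by this assay. The step from compound 3 to compound 4 is expected to be a number no higher from compound 3 to compound 4 (the limit leaves the size open), with a high chance of another limit. Compound 4 is estimated at 100000 nM, within 40000 nM to 300000 nM.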

Compound 4, half-maximal cytotoxic concentration: > 100000 nM
Compound 4: no number, only a limit (the forecaster's own chance of this, stated with the estimate: 65%); the middle value lies on the limit itself.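

Compound 4 gives only a limit in this assay, so the aromatic ring without any group on this carbon also stays unresolved: the limit of > 100000 nM in this assay, at which 3 of the 4 values shown sit.

Hydrogen in place of bromo gives an at least 2.0-fold higher number from compound 1 to compound 4 (0.30 log units; that floor lies within the scatter), the first readable step in the set, though only a floor. The steps from compound 2 and compound 3 to compound 4 cannot be read, as both ends are limits.

Hydrogen, fluoro and methoxy therefore remain unordered against one another. Going by these compounds, whether an amine or a carboxylic acid on this aromatic carbon would give a number rather than a limit stays open.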